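A Methyl Step Carried from One Core to Another

This account rests on a few compounds, and the source may have more. Where it says the series, first, only, none or still open, it means among the compounds named here.

The measured compounds:
Compound 1 `N/C(=N\NC(=S)N1CCCCCC1)c1ccccn1` gives 3000 nM in a functional assay on A-431 cells (Homo sapiens) for cytotoxicity, read by MTT assay, with a stated time of 72 h; a lower number here means a stronger inhibitor, a higher number a weaker inhibitor.
Compound 2 `N/C(=N\NC(=S)N1CCOCC1)c1ccccn1` gives 4800 nM in this assay.
Compound 3 `Cc1cccc(/C(N)=N/NC(=S)N2CCOCC2)n1` gives 4300 nM in this assay.

Compound 2 and compound 3 share a core and differ in one place: methyl in place of hydrogen on an aromatic carbon. That change produced a 1.1-fold lower number from compound 2 to compound 3 (0.05 log units; within the scatter). Compound 1 carries a different core; the difference between the two cores is not broken down here. Among the three measured compounds, compound 1 has the lowest number, but its gaps to compound 3 and compound 2 both lie within the scatter, so no order among them can be read.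

Compound 4 `Cc1cccc(/C(N)=N/NC(=S)N2CCCCCC2)n1` has not yet been measured. It stands to compound 1 as compound 3 stands to compound 2: methyl in place of hydrogen on an aromatic carbon. The place lines of the two changes match word for word, so this is the same change made on the other core. Because a 1.1-fold lower number from compound 2 to compound 3 (0.05 log units; within the scatter) was within the scatter, the account expects little movement in this assay from compound 1 to compound 4 as well: the step is estimated at a 1.1-fold lower number from compound 1 to compound 4 (0.03 log units; within the scatter). The expectation rests on one measured pair only, and on the assumption that the two cores respond alike, which nothing here confirms. For compound 4 the estimate is 2800 nM, expected to fall between 1400 nM and 5600 nM.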

Compound 4, half-maximal inhibitory concentration: 14700 nM
The estimate for compound 4 lay 5.3-fold (0.72 log units) below the measured number; the whole stated range lies below it.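

In this assay, methyl in place of hydrogen on an aromatic carbon gave a 4.9-fold higher number from compound 1 to compound 4 (0.69 log units; beyond the scatter), so on the core of compound 1 the change did not repeat the small step seen on the other core, and the two steps stand apart by more than the scatter: the same change on two cores in this assay, a 1.1-fold lower number (0.05 log units; within the scatter) from compound 2 to compound 3 and a 4.9-fold higher number (0.69 log units; beyond the scatter) from compound 1 to compound 4, 5.5-fold (0.74 log units) apart, beyond the scatter of two such steps

This shows that, for these two cores, the step measured on one could not be carried over to the other, and that the same methyl can matter on one core while leaving no readable change on the other. It does not show why the two cores part, since the data hold a single pair on each core and no measurement that would separate one possible cause from another, nor does it show how the change would behave on any third core.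

As far as these compounds go, whether an ethyl group or a chlorine atom in that same place would follow the methyl on the core of compound 1, or would leave the number as little moved as on the other core, stays open. Also open, from the compounds shown here alone, is whether the higher number belongs to this place alone or would return with a methyl elsewhere on the six-membered aromatic ring.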